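Swapping chloro for fluoro on a spirocyclic amide series

The source may hold more compounds than are shown below. What is called first, only, known or untested is meant among the compounds shown, and "the series" means these compounds.

Compound 1 `CN(C(=O)C(Cc1ccccc1Cl)CN1CCC2(CC1)OCCc1cc(F)sc12)C1CC1` gives 5.52 in a physicochemical assay for lipophilicity, using potentiometric titration, at pH 7.4; on this read-out lower numbers stand for lower lipophilicity and higher numbers for higher lipophilicity.
Compound 2 `CNC(=O)C(Cc1ccccc1Cl)CN1CCC2(CC1)OCCc1cc(Cl)sc12` gives 3.77 in this assay.
Compound 3 `CNC(=O)C(Cc1ccccc1F)CN1CCC2(CC1)OCCc1cc(Cl)sc12` gives 4.19 in this assay.

Of the compounds shown here, three have been measured in this assay, and a fourth, compound 4 `CN(C(=O)C(Cc1ccccc1F)CN1CCC2(CC1)OCCc1cc(F)sc12)C1CC1`, has not. Compound 1 stands highest of the three; compound 3 lies nearest to it and compound 2 furthest, both beyond the scatter. How the core of compound 1 differs from the core of compound 2 is not broken down here; the two differ in more than one place.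

Between compound 2 and compound 3 the change is fluoro in place of chloro on an aromatic carbon. That change produced a number 0.42 log units higher from compound 2 to compound 3 (beyond the scatter). Within the data shown here, the change from compound 1 to compound 4 is fluoro in place of chloro on an aromatic carbon, the same change at the same kind of place, so the measured step between compound 2 and compound 3 is the only guide available for it.

On that basis compound 4 is expected to sit above compound 1 by a step of about a number 0.38 log units higher from compound 1 to compound 4 (beyond the scatter), resting on the step of a number 0.42 log units higher from compound 2 to compound 3 (beyond the scatter) seen between compound 2 and compound 3. Among the measured compounds shown here, the estimate for compound 4 in this assay is therefore 5.9, with a range from 5.3 to 6.5, since only one earlier instance of the change supports it.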

Compound 4, distribution coefficient: 4.77
Compound 4: middle estimate off by 1.13 log units, on the high side; the measured number lies below the stated range.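

In this assay the change from 2-chlorobenzyl to 2-fluorobenzyl gave a number 0.75 log units lower from compound 1 to compound 4 (beyond the scatter) on one core and a number 0.42 log units higher from compound 2 to compound 3 (beyond the scatter) on the other, so the same change moved the number in opposite directions, with each step printed as beyond the scatter. This shows that, for these two pairs, neither the direction nor the size of the step carried over from one core to the other, though it does not show which of the several differences between the two cores goes with the reversal, or what the change would do on a third core, and two pairs establish no rule for the series. Nothing given here bears on why the direction differs between the two cores.

The compounds shown leave open whether a core differing from either of these in one place only would give the upward step or the downward one. They also leave open how bromo, methyl, methoxy or a nitrile would behave on that aromatic carbon, and whether any of these groups would respond to the core in the way that fluoro does.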